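The source may report more compounds than this note shows. Statements on the series, on what has been measured and on what is new or still open speak of the compounds shown alone.

Among the compounds with values here, in an assay on HEK293 cells for antagonist activity at transient receptor potential M8 protein (Canis lupus familiaris), read by fluorescence and calcium flux, with a stated time of 5 min (on this read-out higher numbers stand for weaker inhibition and lower numbers for stronger inhibition), compound 3, drawn as `O=C(C(Nc1ccccc1)c1ccc(C(F)(F)F)cc1)N1CCC[C@H]1c1ccccc1Cl`, gives 41 nM, the second highest of the three numbers known so far. Its nearest neighbour is compound 2, `O=C(C(Nc1ccccc1)c1ccc(C(F)(F)F)cc1)N1CCCC1c1ccccc1F`, which in this assay gives 30 nM; the furthest is compound 1, `O=C(C(Nc1ccccc1)c1ccc(C(F)(F)F)cc1)N1CCCC1c1ccccc1`, which gives 60 nM. Both of these gaps lie within the scatter, so the three measured compounds cannot be told apart on potency.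

Compound 4, `O=C(C(Nc1ccccc1)c1ccc(C(F)(F)F)cc1)N1CCC[C@@H]1c1ccccc1Cl`, differs from compound 3 only in that (the two compounds have the same atoms and bonds; at least one stereo element is drawn with a configuration in one of them and without one in the other: 1 of 2 stereo elements differ; a stereocentre at a saturated ring carbon is drawn S in compound 3 and R in compound 4). Within the data shown here, no measured step bears on this change: the single recorded step, a 2.0-fold lower number from compound 1 to compound 2 (0.30 log units; within the scatter), concerns a fluorine for hydrogen swap on an aromatic ring and says nothing about the ring stereocentre, and compounds 1 and 2 carry no drawn configuration at that carbon at all. The expectation for compound 4 therefore rests on the general observation that swapping the configuration at a stereocentre often weakens binding, so a step of a 3.7-fold higher number from compound 3 to compound 4 (0.56 log units; beyond the scatter) towards a higher number is expected, with wide uncertainty. Compound 4 is estimated at 150 nM, within 40 nM to 800 nM.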

Compound 4, half-maximal inhibitory concentration: 168 nM
Beside the measured number, compound 4's estimate is 1.1-fold (0.05 log units) below it, and the stated range covers the measured number.
By their numbers in this assay, from the lowest: compounds 2, 3 and 1 (each within the scatter of the next); then compound 4.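

In this assay, inverting the saturated ring carbon from S to R gives a 4.1-fold higher number from compound 3 to compound 4 (0.61 log units; beyond the scatter). This is the first step shown that lies beyond the scatter, and it comes with no change of atoms or bonds, so the spatial arrangement at this one carbon matters in a way the earlier, indistinguishable compounds could not reveal. The reading of this step still rests on how the two structures are drawn: the fact that one of compounds 3 and 4 is drawn with a defined configuration and the other without, at the place where they differ

Going by these compounds, compounds 1 and 2 carry no drawn configuration at this carbon, so it remains open whether the same preference holds with hydrogen or fluoro on the aromatic ring, or with a methoxy group or a nitrile there instead. On these data alone, the effect of the second stereo element, which the drawings leave undefined, also remains open.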